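The source may report more compounds than this note shows. Statements on the series, on what has been measured and on what is new or still open speak of the compounds shown alone.

Within the data shown here, the two compounds measured so far share one core and differ only in the group on the carbonyl carbon. Compound 1, `COc1cccc(C(=O)Nc2cc(-c3ccccc3)nn2-c2ccccc2)c1`, carries a 3-methoxyphenyl there; in an assay on HEK293 cells for displacement of a labelled ligand from metabotropic glutamate receptor 5 (Rattus norvegicus) (a lower number here means a stronger inhibitor, a higher number a weaker inhibitor), compound 1 gives 1290 nM. Compound 2, `NC(=O)c1ccc(C(=O)Nc2cc(-c3ccccc3)nn2-c2ccccc2)cc1`, carries a 4-carbamoylphenyl in the same place. In this assay, among the measured compounds shown here, compound 2 gives > 10000 nM, which is not a number but a limit of the assay, and compound 2 is the one value that sits at the limit of > 10000 nM in this assay, at which 1 of the 2 values shown sits. The change of group thus gave an at least 7.7-fold higher number from compound 1 to compound 2 (0.88 log units; beyond the scatter), so compound 2 stands at the weak end of what has been measured.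

Compound 3, `O=C(Nc1cc(-c2ccccc2)nn1-c1ccccc1)C1=CCCCC1`, keeps the core and again replaces the group on the carbonyl carbon: cyclohex-1-en-1-yl in place of 4-carbamoylphenyl on a carbonyl carbon. For the measured compounds named here, only the single step from compound 1 to compound 2 touches this position, and it shows that exchanging 3-methoxyphenyl for 4-carbamoylphenyl weakened binding at least modestly. Whether cyclohex-1-en-1-yl recovers part of that loss cannot be read from two values; the expectation for this assay is a number between them. Compound 3 is therefore expected to give 3500 nM, with a range from 800 nM to 12000 nM, an expected step of an at least 2.8-fold lower number from compound 2 to compound 3 (0.45 log units; beyond the scatter).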

Compound 3, inhibition constant: 4470 nM
The estimate for compound 3 lay 1.3-fold (0.11 log units) below the measured number; the measured number falls inside the stated range.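

In this assay, the position on the carbonyl carbon now carries a third group, and this places the three compounds in an order: cyclohex-1-en-1-yl in place of 4-carbamoylphenyl gives an at least 2.2-fold lower number from compound 2 to compound 3 (0.34 log units; beyond the scatter), while cyclohex-1-en-1-yl in place of 3-methoxyphenyl gives a 3.5-fold higher number from compound 1 to compound 3 (0.54 log units; beyond the scatter). The position therefore keeps a measurable number with a non-aromatic ring of carbon only, which has no hydrogen-bond donors or acceptors, although that ring does not match the 3-methoxyphenyl of compound 1. For compound 2, > 10000 nM is a limit and not a number, so the gain from compound 2 can be stated only as a bound: the limit of > 10000 nM in this assay, at which 1 of the 3 values shown sits.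

Compound 3 differs from compound 1 and from compound 2 in the ring and in the substituent at once, so the compounds shown cannot tell how much of either step belongs to the ring and how much to the methoxy or carbamoyl group. As far as these compounds go, an unsubstituted phenyl, a saturated cyclohexyl or a ring carrying a carboxylic acid or an amine at this position would separate these contributions, and how any of them would fare remains open.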